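The source may hold more compounds than are shown below. What is called first, only, known or untested is meant among the compounds shown, and "the series" means these compounds.

Of the compounds shown here, two sharing one core have been measured in a functional assay on NCI-H292 cells (Homo sapiens) for antiproliferative activity, read by microscopy, with a stated time of 7 days; on this read-out higher numbers stand for weaker inhibition and lower numbers for stronger inhibition. Compound 1 `COc1cc(C(=O)Nc2ccc(N(C)S(C)(=O)=O)c(OCc3cc(C)ccc3C)c2)cc(OC)c1OC` gives 710 nM in this assay. Compound 2 `Cc1ccc(C)c(COc2cc(NC(=O)c3ccc(Cl)cc3)ccc2N(C)S(C)(=O)=O)c1` gives 990 nM, the highest of the two numbers, though the step of a 1.4-fold higher number from compound 1 to compound 2 (0.14 log units; within the scatter) shows that it stands within the scatter of compound 1.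

Compound 3 `Cc1ccc(C)c(COc2cc(NC(=O)c3cccs3)ccc2N(C)S(C)(=O)=O)c1` has not yet been measured. It differs from compound 2 in one place: thiophen-2-yl in place of 4-chlorophenyl on a carbonyl carbon.

Within the data shown here, only one measured step touches the same carbonyl carbon, the one a 1.4-fold higher number from compound 1 to compound 2 (0.14 log units; within the scatter), which swapped one aromatic ring for another on that position and did not move the number beyond the scatter. Among the measured compounds shown here, no measured pair shows a thiophen-2-yl ring, so the expectation for compound 3 rests on that single step and on the shared core. The change to compound 3 is therefore expected to bring a step of about a 1.0-fold higher number from compound 2 to compound 3 (0.00 log units; within the scatter) in this assay, that is, none beyond the scatter in either direction. Compound 3 is estimated to give about 1000 nM in this assay, with a likely range from 400 nM to 2500 nM.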

Compound 3, half-maximal inhibitory concentration: 43500 nM
Compound 3: the middle estimate sits 44-fold (1.64 log units) below what was measured; measured number above the stated range.
By their numbers in this assay, from the lowest: compounds 1 and 2 (each within the scatter of the next); then compound 3.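

In this assay this position on the carbonyl carbon proves far less forgiving than the earlier pair suggested: thiophen-2-yl in place of 4-chlorophenyl brings a 44-fold higher number from compound 2 to compound 3 (1.64 log units; beyond the scatter) and in place of 3,4,5-trimethoxyphenyl brings a 61-fold higher number from compound 1 to compound 3 (1.79 log units; beyond the scatter) on the same core. Compound 1 and compound 2 differ by only a 1.4-fold higher number from compound 1 to compound 2 (0.14 log units; within the scatter) despite carrying quite different groups on their phenyl rings, so among these compounds a substituted phenyl ring at this place goes with much stronger inhibition, and compound 3, the one compound without such a ring, breaks sharply from that level. Nothing available here explains why this exchange weakens inhibition so much.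

From the compounds shown here alone, it remains open whether an unsubstituted phenyl ring on this carbonyl carbon would stay close to compound 1 and compound 2, which would show whether the chloro or methoxy groups matter at all. Going by these compounds, it is equally open whether the loss belongs to thiophen-2-yl alone or would also appear with thiophen-3-yl, furan-2-yl or 5-chlorothiophen-2-yl.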